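Ethyl in place of bromo at the assay limit

A few compounds are considered here, and "the series" means these few. Any claim that something is new, unique, unknown or untested is made for them only; others in the source may bear on it.

Three compounds have entries in a functional assay on MGC-803 cells (Homo sapiens) for antiproliferative activity, read by CCK-8 assay, with a stated time of 72 h; a lower number here means a stronger inhibitor, a higher number a weaker inhibitor. Compound 1 `C/C(=N\O)c1ccc(OCc2ccc(C(=O)NO)cc2)cc1` stands at "not determined" (no result reported). Compound 2 `Nc1ccccc1NC(=O)c1ccc(COc2ccc(Br)cc2)cc1` gives > 32000 nM, which is a limit and not a number. Compound 3 `Nc1ccccc1NC(=O)/C=C/c1ccc(COc2ccccc2)cc1` gives > 32000 nM, which is also a limit. The position of compound 2 is therefore (the limit of > 32000 nM in this assay, at which 2 of the 3 values shown sit). Within the data shown here, no numerical potency is available so far, and no two measured compounds differ in one place.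

Compound 4 `CCc1ccc(OCc2ccc(C(=O)Nc3ccccc3N)cc2)cc1` has not yet been measured. It carries ethyl in place of bromo on an aromatic carbon, para to a large group: ethyl in place of bromo on an aromatic carbon. With compound 2 at > 32000 nM, a limit, no change beyond the scatter is expected in this assay, in either direction. The expected move is an at least 1.0-fold lower number from compound 2 to compound 4 (0.02 log units; that floor lies within the scatter), and a report as a limit alone is more likely than a number. Compound 4 is estimated at 30000 nM, with an expected range of 12000 nM to 64000 nM.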

Compound 4, half-maximal inhibitory concentration: 5880 nM
Estimate against measurement, compound 4: 5.1-fold (0.71 log units) above, and the stated range ends above it.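

In this assay, the change from 4-bromophenyl to 4-ethylphenyl gives the only numerical potency among the compounds shown, and the step reads an at least 5.4-fold lower number from compound 2 to compound 4 (0.73 log units; beyond the scatter). The earlier compounds shown here gave no sign that this position could matter, whereas this single change, on an aromatic carbon para to a large group, moves the read-out off the limit. The full size of the step cannot be read because compound 2 stands at a limit and not at a number: the limit of > 32000 nM in this assay, at which 2 of the 4 values shown sit.

On these data alone, whether a longer chain such as propyl, an amine or a carboxylic acid at this position would hold or extend the gain in this assay remains open. Also open, as far as these compounds go, is whether ethyl has the same effect on the core of compound 3.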